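Cytotoxicity notes on compounds 1 to 4

The source may report more compounds than this note shows. Statements on the series, on what has been measured and on what is new or still open speak of the compounds shown alone.

Values in an ADME assay on WI-38 cells (Homo sapiens) for cytotoxicity, read by MTT assay, with a stated time of 72 h (a lower number here means a stronger inhibitor, a higher number a weaker inhibitor), each one a limit of the assay and not a number:
compound 1 `COc1cc(OC)cc(-c2cccc(NC(=O)CCc3cccc4c3COB4O)c2)c1`: > 100000 nM
compound 2 `CC(=O)c1ccc(-c2cccc(NC(=O)CCc3cccc4c3COB4O)c2)cc1`: > 100000 nM
compound 3 `COc1cc(OC)cc(-c2cccc(NC(=O)CCc3ccccc3)c2)c1`: > 100000 nM

All three measured compounds sit at the limit of > 100000 nM in this assay, at which 3 of the 3 values shown sit, so no ordering among them can be read. From compound 1 to compound 2 the change is 4-acetylphenyl in place of 3,5-dimethoxyphenyl on an aromatic carbon, and the step is a step that the two limits leave unreadable from compound 1 to compound 2. From compound 1 to compound 3 the change is a group of 6 heavy atoms (6 carbon; one six-membered aromatic ring of carbon only) in place of a group of 10 heavy atoms (7 carbon, 1 boron, 2 oxygen; one five-membered non-aromatic ring with 2 hetero atoms, one six-membered aromatic ring of carbon only), on a saturated chain carbon, two bonds along the chain from a carbonyl carbon, and the step is a step that the two limits leave unreadable from compound 1 to compound 3.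

Compound 4 `CC(=O)c1ccc(-c2cccc(NC(=O)CCc3ccccc3)c2)cc1` is not yet measured in this assay. For the measured compounds named here, it differs from compound 2 by a group of 6 heavy atoms (6 carbon; one six-membered aromatic ring of carbon only) in place of a group of 10 heavy atoms (7 carbon, 1 boron, 2 oxygen; one five-membered non-aromatic ring with 2 hetero atoms, one six-membered aromatic ring of carbon only), on a saturated chain carbon, two bonds along the chain from a carbonyl carbon, which is the same change, at the same place, as the one from compound 1 to compound 3. The two cores differ by 4-acetylphenyl in place of 3,5-dimethoxyphenyl on an aromatic carbon.

The step from compound 2 to compound 4 in this assay is expected to be a step that the limit leaves unreadable from compound 2 to compound 4, an expectation resting on compound 2 sitting at the limit of > 100000 nM in this assay, at which 3 of the 3 values shown sit, and on compound 3 also sitting at the limit of > 100000 nM in this assay, at which 3 of the 3 values shown sit, after the same change. Compound 4 is therefore estimated at 200000 nM, with a range from 80000 nM to 600000 nM, and a limit rather than a number is the more likely outcome for compound 4.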

Compound 4, half-maximal inhibitory concentration: 13000 nM
Compound 4: middle estimate off by 15-fold (1.19 log units), on the high side, and the stated range ends above it.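

In this assay, on these data alone, phenyl in place of the group of 10 heavy atoms, on a saturated chain carbon, two bonds along the chain from a carbonyl carbon, gives an at least 7.6-fold lower number from compound 2 to compound 4 (0.88 log units; beyond the scatter), so on the core of compound 2 the change has a readable effect whose full size stays open. The same change on the core of compound 1 cannot be read, and neither can the other steps among the limit values, so the result neither confirms nor refutes that the change carries from one core to the other: the limit of > 100000 nM in this assay, at which 3 of the 4 values shown sit. This is a single readable pair on a single core, so it shows what the change did to compound 2 and sets no rule for the series, and it gives no cause for the lower number of compound 4.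

The compounds shown leave open whether other aryl groups on the shared core would give a number with phenyl on the saturated chain, or whether this is confined to 4-acetylphenyl. They also leave open how the number would respond to an amine or a carboxylic acid on the entering phenyl, or to a longer chain carrying it.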